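Notes on the amide side chain of the piperazine series

The compounds below may be only part of what the source reports. "The series", "measured", "known", "first", "only" and "open" are said of these compounds alone.

Measured compounds:
- compound 1, `CC(C)C[C@H](N)c1cc(C(F)(F)F)ccc1N1CCN(C(=O)CNc2ccccc2)CC1`, 3600 nM
- compound 2, `CC(C)C[C@H](N)c1cc(C(F)(F)F)ccc1N1CCN(C(=O)C(C)Cc2ccc(Cl)cc2)CC1`, 47 nM
- compound 3, `CC(C)C[C@H](N)c1cc(C(F)(F)F)ccc1N1CCN(C(=O)CCNC2CCCCC2)CC1`, 4800 nM

In an assay on HEK293 cells for displacement of a labelled ligand from Melanocortin receptor 4 (Homo sapiens) (a higher number here means a weaker inhibitor, a lower number a stronger inhibitor), compound 1 stands second highest of the three numbers, close to compound 3 and far from compound 2. The step of a 1.3-fold higher number from compound 1 to compound 3 (0.12 log units; within the scatter) is within the scatter, whereas a 77-fold lower number from compound 1 to compound 2 (1.88 log units; beyond the scatter) is large and beyond it; a 100-fold higher number from compound 2 to compound 3 (2.01 log units; beyond the scatter) runs the same distance back.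

Compound 4, `CC(C)C[C@H](N)c1cc(C(F)(F)F)ccc1N1CCN(C(=O)COc2cccc(Cl)c2)CC1`, is not yet measured. It differs from compound 1 by 3-chlorophenoxy in place of anilino on a saturated chain carbon bound to a carbonyl carbon. Going by the values given here, of the measured steps, only the one from compound 1 to compound 2 bears on it, since both replace the anilino motif, which carries a hydrogen-bond donor, by a chlorine-bearing aromatic group with no donor; compound 4 keeps the chain length of compound 1, so the full gain seen in that step is not assumed. A lower number than for compound 1 is expected in this assay, beyond the scatter but smaller than the step to compound 2: the estimated step is a 4.5-fold lower number from compound 1 to compound 4 (0.65 log units; beyond the scatter). For compound 4 the estimate is 800 nM, with a range from 200 nM to 3000 nM.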

Compound 4, inhibition constant: 2600 nM
Beside the measured number, compound 4's estimate is 3.3-fold (0.51 log units) below it; low and high end bracket the measured number.
By their numbers in this assay, from the lowest: compound 2; then compounds 4, 1 and 3 (each within the scatter of the next).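

In this assay, exchanging anilino, with its hydrogen-bond donor, for 3-chlorophenoxy, with none, gives a 1.4-fold lower number from compound 1 to compound 4 (0.14 log units; within the scatter) and so stays within the scatter: on a saturated chain carbon bound to a carbonyl carbon, losing that donor and adding a chlorine-bearing ring together do not reproduce the gain of compound 2. The same reading holds for a 1.8-fold lower number from compound 3 to compound 4 (0.27 log units; within the scatter), so compounds 1, 3 and 4 cannot be told apart here. Compound 2 alone stands apart, with a 55-fold higher number from compound 2 to compound 4 (1.74 log units; beyond the scatter) as a large step, and among the groups shown the gain stays with 1-(4-chlorobenzyl)ethyl as a whole.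

From the compounds shown here alone, whether that gain needs the methyl branch, the 4-chlorobenzyl group or a chain free of oxygen and nitrogen stays open, and an unbranched 2-(4-chlorophenyl)ethyl group on the carbonyl carbon would help to separate these. Nothing available here accounts for any of these steps.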